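The source may hold more compounds than are shown below. What is called first, only, known or untested is meant among the compounds shown, and "the series" means these compounds.

- compound 1 `COc1ccc(Nc2nc3c(c(Oc4cccc(NC(=O)C=C(C)C)c4)n2)CSCC3)cc1` gives 19100 nM 
- compound 2 `C/C=C/C(=O)Nc1cccc(Oc2nc(Nc3ccc(OC)nc3)nc3c2CSCC3)c1` gives 16500 nM 
- compound 3 `CC/C=C/C(=O)Nc1cccc(Oc2nc(Nc3ccc(OC)nc3)nc3c2CSCC3)c1` gives 31200 nM 

All three were tested in a functional assay on HeLa cells (Homo sapiens) for antiproliferative activity, read by MTT assay, with a stated time of 72 h (a higher number here means a weaker inhibitor, a lower number a stronger inhibitor), and compound 3 stands within the scatter of both compound 1 and compound 2, so these numbers give no ranking. Compound 4 `COc1ccc(Nc2nc3c(c(Oc4cccc(NC(=O)C=C(C)C)c4)n2)CSCC3)cn1` has the same atoms as compound 3, joined differently: 2-methylprop-1-en-1-yl in place of but-1-en-1-yl on a carbonyl carbon on a carbonyl carbon. Going by the values given here, the one measured step that bears on this, a 1.9-fold higher number from compound 2 to compound 3 (0.28 log units; within the scatter), also alters the group on that carbonyl carbon, and it stayed small. Compound 1 already carries 2-methylprop-1-en-1-yl and gives 19100 nM on a different remainder. No step beyond the scatter is therefore expected in this assay for this change. An estimate of a 1.5-fold lower number from compound 3 to compound 4 (0.17 log units; within the scatter) is what this expectation means. For compound 4 the expected value is 21000 nM (estimated range 10000 nM to 43000 nM).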

Compound 4, half-maximal inhibitory concentration: 29200 nM
The estimate for compound 4 lay 1.4-fold (0.14 log units) below the measured number, within the range that was stated.
By their numbers in this assay, from the lowest: compounds 2, 1, 4 and 3 (each within the scatter of the next).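

In this assay, 2-methylprop-1-en-1-yl in place of but-1-en-1-yl on the carbonyl carbon gives a 1.1-fold lower number from compound 3 to compound 4 (0.03 log units; within the scatter), and in place of prop-1-en-1-yl it gives a 1.8-fold higher number from compound 2 to compound 4 (0.25 log units; within the scatter), so this assay does not separate these three chains. A direct comparison on the other side of the molecule, 6-methoxypyridin-3-yl in place of 4-methoxyphenyl on the nitrogen, gives a 1.5-fold higher number from compound 1 to compound 4 (0.18 log units; within the scatter), so that change does not register either. No measurement shown here accounts for these numbers. As far as these compounds go, whether an amine, a carboxylic acid or a longer chain at the carbonyl carbon would shift the number remains open.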